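Bromo substitution on two related cores: sigma binding notes

A few compounds are considered here, and "the series" means these few. Any claim that something is new, unique, unknown or untested is made for them only; others in the source may bear on it.

Measured so far:
Compound 1, `CN(CCCn1c(=O)oc2ccccc21)Cc1ccccc1`: > 100 nM
Compound 2, `CN(CCCn1c(=O)oc2cc(Br)ccc21)Cc1ccccc1`: 0.9 nM
Compound 3, `CN(CCCn1c(=O)sc2ccccc21)Cc1ccccc1`: 10.3 nM

In an assay on Jurkat cells for displacement of a labelled ligand from Sigma non-opioid intracellular receptor 1 (Homo sapiens), read by scintillation counting, with a stated time of 120 min (a lower number here means a stronger inhibitor, a higher number a weaker inhibitor), compound 1 reaches only a limit, > 100 nM, which is the limit of > 100 nM in this assay, at which 1 of the 3 values shown sits. Compound 2 carries bromo in place of hydrogen on an aromatic carbon, and the step is an at least 110-fold lower number from compound 1 to compound 2 (2.04 log units; beyond the scatter). Compound 3 has a core whose difference from the core of compound 1 is not broken down here; in this assay compound 3 gives 10.3 nM, a higher number than compound 2 shows.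

Compound 4, `CN(CCCn1c(=O)sc2ccc(Br)cc21)Cc1ccccc1`, applies the same change to compound 3: bromo in place of hydrogen on an aromatic carbon. This change occurs twice among these compounds, with the same place words each time. Going by these compounds, a large step is expected because an at least 110-fold lower number from compound 1 to compound 2 (2.04 log units; beyond the scatter) was large, though from a limit its full size is unknown. The expected step from compound 3 is a 10-fold lower number from compound 3 to compound 4 (1.01 log units; beyond the scatter). Compound 4 is therefore estimated at 1 nM, between 0.3 nM and 4 nM.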

Compound 4, inhibition constant: 3.1 nM
Beside the measured number, compound 4's estimate is 3.1-fold (0.49 log units) below it; low and high end bracket the measured number.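

In this assay, bromo in place of hydrogen on an aromatic carbon again gives a lower number on the second core (a 3.3-fold lower number from compound 3 to compound 4 (0.52 log units; beyond the scatter)), so the direction carries over in this pair, but the size does not: the same change on two cores in this assay, an at least 110-fold lower number (2.04 log units; beyond the scatter) from compound 1 to compound 2 and a 3.3-fold lower number (0.52 log units; beyond the scatter) from compound 3 to compound 4, at least 33-fold (1.52 log units) apart, beyond the scatter of two such steps.

Going by these compounds, compound 1 stands at a limit (> 100 nM), so the full size of the step from it stays unknown.

Two cores give no rule for a further core, and what sets the size of the step on each core is not shown.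

On these data alone, whether chloro or methoxy in place of bromo would follow the same course on both cores stays open. So does the outcome of a longer chain carrying the amine.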